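Methyl on the piperazine ring: compound 2 to compound 3

The compounds below may be only part of what the source reports. "The series", "measured", "known", "first", "only" and "open" are said of these compounds alone.

Measured so far:
compound 1, `O=C(Nc1ncccc1N1CCN(C(=O)Cn2cnc3cccnc32)CC1)c1cccc(Cl)c1`: 177 nM
compound 2, `O=C(Cn1cnc2cccnc21)N1CCN(c2scnc2-c2nc3ccccc3[nH]2)CC1`: 30 nM

In a functional assay on CHO-K1 cells for antagonist activity at C-X-C chemokine receptor type 3 (Homo sapiens), read by FLIPR, with a stated time of 10 min (a higher number here means a weaker inhibitor, a lower number a stronger inhibitor), compound 2 gives the lower of the two numbers. Compound 1 gives a number higher than that of compound 2 by a margin beyond the usual scatter, so compound 2 stands as the stronger of the two measured entries. Going by the values given here, only two compounds have been run, and no pair differing in a single place has been measured, so no step size has yet been observed.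

Compound 3, `C[C@H]1CN(c2scnc2-c2nc3ccccc3[nH]2)CCN1C(=O)Cn1cnc2cccnc21`, has not been measured. It differs from compound 2 by methyl in place of hydrogen on a saturated ring carbon. Among the compounds with values here, with no comparable step in hand, the expectation is that a change of this size leaves the number near that of compound 2, and the step from compound 2 to compound 3 is estimated as a 1.3-fold higher number from compound 2 to compound 3 (0.12 log units; within the scatter), none beyond the scatter. For compound 3 the estimate in this assay is 40 nM, with a range from 10 nM to 160 nM.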

Compound 3, half-maximal inhibitory concentration: 67 nM
For compound 3 the middle estimate is 1.7-fold (0.22 log units) below the measured one; the measured number falls inside the stated range.
By their numbers in this assay, from the lowest: compound 2; then compound 3; then compound 1.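

Going by these compounds alone, this is the first step that changes one place only. In this assay, methyl in place of hydrogen on a saturated ring carbon gives a 2.2-fold higher number from compound 2 to compound 3 (0.35 log units; beyond the scatter), a modest loss of inhibition. The position, next to the ring nitrogen, therefore responds to the addition of a single heavy atom by more than the usual scatter, though one step cannot define a trend, and nothing available explains the size of this step.

As far as these compounds go, whether an ethyl or a hydroxymethyl group on this ring carbon would widen or narrow the step remains open. Also open, from the compounds shown here alone, is whether methyl on this ring carbon would have a similar effect with the core of compound 1, or at the other saturated ring carbons of the six-membered ring.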